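Four-fluorophenyl amide in the pyridine N-oxide piperidine series

The source may hold more compounds than are shown below. What is called first, only, known or untested is meant among the compounds shown, and "the series" means these compounds.

Measured compounds:
Compound 1, `CCc1cccc(NC(=O)CN2CCC(c3cccc[n+]3[O-])CC2)c1`, 95 nM
Compound 2, `O=C(CN1CCC(c2cccc[n+]2[O-])CC1)Nc1cccc(Cl)c1Cl`, 180 nM
Compound 3, `Cc1cc(Br)ccc1NC(=O)CN1CCC(c2cccc[n+]2[O-])CC1`, 66 nM

Three compounds that share one core and differ only in the aryl group on the amide-type nitrogen have been measured in a functional assay on HEK293 cells for agonist activity at D(4) dopamine receptor (Homo sapiens), read by FLIPR; a higher number here means that more compound is needed for the effect, a lower number that less compound is needed. Compound 3 gives 66 nM, the lowest of the three numbers. The step of a 1.4-fold lower number from compound 1 to compound 3 (0.16 log units; within the scatter) lies within the scatter, so the two compounds cannot be told apart. Its step from compound 2 is a 2.7-fold lower number from compound 2 to compound 3 (0.44 log units; beyond the scatter), a modest but real separation. The step of a 1.9-fold higher number from compound 1 to compound 2 (0.28 log units; within the scatter) lies within the scatter as well.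

Compound 4, `O=C(CN1CCC(c2cccc[n+]2[O-])CC1)Nc1ccc(F)cc1`, has not yet been measured in this assay. It differs from compound 3 in this way: 4-fluorophenyl in place of 4-bromo-2-methylphenyl on an amide-type nitrogen. Within the data shown here, no measured step exchanges a 4-fluorophenyl for anything, so the three steps only show how far aryl changes at this position have moved the number so far: at most modestly, as in the step from compound 2 to compound 3. Compound 4 is therefore expected to stay in the same region, with a modest rise as the more likely direction, an expected step of a 2.7-fold higher number from compound 3 to compound 4 (0.44 log units; beyond the scatter). The estimate for compound 4 in this assay is 180 nM, within a range of 60 nM to 550 nM.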

Compound 4, half-maximal effective concentration: 85 nM
Compound 4: middle estimate off by 2.1-fold (0.33 log units), on the high side; the range from low to high includes it.
By their numbers in this assay, from the lowest: compounds 3, 4, 1 and 2 (each within the scatter of the next, the first and the last beyond it).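

In this assay, replacing the 4-bromo-2-methylphenyl on the amide-type nitrogen with 4-fluorophenyl does not separate the two compounds (a 1.3-fold higher number from compound 3 to compound 4 (0.11 log units; within the scatter)), and the same holds for replacing 3-ethylphenyl with 4-fluorophenyl (a 1.1-fold lower number from compound 1 to compound 4 (0.05 log units; within the scatter)). Among these compounds, then, an aryl group bearing only a fluorine cannot be told apart from the two aryl groups that bear an alkyl group, so neither the methyl nor the ethyl group is needed to stay level with compound 1 and compound 3. The 4-fluorophenyl does separate from the 2,3-dichlorophenyl of compound 2 (a 2.1-fold lower number from compound 2 to compound 4 (0.33 log units; beyond the scatter)), a modest step that gives this position a second aryl group, after the 4-bromo-2-methylphenyl of compound 3, lying beyond the scatter from the 2,3-dichlorophenyl.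

The compounds shown leave open what the fluorine itself contributes, since a plain phenyl group does not appear among them to compare with compound 4. They also leave open how this position responds to an aryl group carrying an amine or a carboxylic acid, or to a longer chain in place of the aryl group.

No measurement at hand bears on why these numbers fall as they do.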